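The compounds below may be only part of what the source reports. "The series", "measured", "known", "first", "only" and "open" are said of these compounds alone.

The measured compounds are:
compound 1, `C=CCCCn1c(Cc2cc(OC)c(OC)c(OC)c2)nc2c(N)nc(F)nc21`, with 44700 nM in a functional assay on MCF7 cells (Homo sapiens) for antiproliferative activity; on this read-out lower numbers stand for stronger inhibition and higher numbers for weaker inhibition;
compound 2, `CCCCCn1c(Cc2cc(OC)c(OC)c(OC)c2)nc2c(N)nc(F)nc21`, with 36300 nM;
compound 3, `CCCCn1c(Cc2cc(OC)c(OC)c(OC)c2)nc2c(N)nc(F)nc21`, with 24000 nM.

All three share one core and differ only in the chain on the ring nitrogen. Compound 3 stands with the lowest number of the three, but its gaps to compound 2 and to compound 1 are both within the scatter of the assay, so no order among them can be claimed. Compound 2 and compound 1 differ by vinyl in place of ethyl on a saturated chain carbon, three bonds along the chain from an aromatic nitrogen, and that change gave a 1.2-fold higher number from compound 2 to compound 1 (0.09 log units; within the scatter), a step that is itself within the scatter.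

Compound 4, `C=CCCn1c(Cc2cc(OC)c(OC)c(OC)c2)nc2c(N)nc(F)nc21`, has not yet been measured. It differs from compound 3 by vinyl in place of ethyl on a saturated chain carbon, two bonds along the chain from an aromatic nitrogen. For the measured compounds named here, this is the same kind of change as the one between compound 2 and compound 1, but not the same: there the place is three bonds along the chain from the aromatic nitrogen, here it is two bonds along the chain. The two starting cores, compound 2 and compound 3, differ by hydrogen in place of methyl on a saturated chain carbon, four bonds along the chain from an aromatic nitrogen.

Given that the earlier change of this kind gave a 1.2-fold higher number from compound 2 to compound 1 (0.09 log units; within the scatter), compound 4 is expected to move by about a 1.2-fold higher number from compound 3 to compound 4 (0.07 log units; within the scatter), that is, to stay close to compound 3. The estimate for compound 4 in this assay is 28000 nM, with a range from 12000 nM to 70000 nM.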

Compound 4, half-maximal inhibitory concentration: 33100 nM
Beside the measured number, compound 4's estimate is 1.2-fold (0.07 log units) below it; the range from low to high includes it.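

In this assay, vinyl in place of ethyl gave a 1.4-fold higher number from compound 3 to compound 4 (0.14 log units; within the scatter), and the change carried from one core to the other with no difference that can be told apart: the same change on two cores in this assay, a 1.2-fold higher number (0.09 log units; within the scatter) from compound 2 to compound 1 and a 1.4-fold higher number (0.14 log units; within the scatter) from compound 3 to compound 4, 1.1-fold (0.05 log units) apart, within the scatter of two such steps. The chain on compound 4 also stays close to the two other chains, with a 1.1-fold lower number from compound 2 to compound 4 (0.04 log units; within the scatter) and a 1.4-fold lower number from compound 1 to compound 4 (0.13 log units; within the scatter), so the four compounds cannot be put in any order on this read-out. For the compounds shown here, what this shows is that the change leaves the number within the scatter at both places along the chain, but it does not show a fixed, transferable effect of the change, as neither step can be told apart from no step at all, and two cores that are this similar are a narrow test.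

The compounds shown hold only plain hydrocarbon chains, so it stays open whether a longer chain, or a chain carrying an amine or a carboxylic acid, would move the number beyond the scatter. Going by these compounds, it also stays open whether vinyl in place of ethyl would stay as small a step on a core with chlorine in place of the fluorine.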